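A Methoxy Group Added to the Phenyl of Compound 3

The compounds below may be only part of what the source reports. "The series", "measured", "known", "first", "only" and "open" are said of these compounds alone.

Of the compounds shown here, three with a shared core have been measured in an assay on membranes from brain for displacement of a labelled ligand from adenosine receptor A1 (Rattus norvegicus), read by scintillation counting, with a stated time of 90 min; a lower number here means a stronger inhibitor, a higher number a weaker inhibitor. Compound 3, `O=C(CCCc1ccccc1)Nc1nc2ccccc2c(=O)s1`, gives 229 nM. Compound 1, `COc1cccc(CCC(=O)Nc2nc3ccccc3c(=O)s2)c1`, gives 367 nM. Compound 2, `O=C(CCCc1ccccc1)Nc1nc2ccc(Cl)cc2c(=O)s1`, reaches only the limit of the assay at > 10000 nM and has no number of its own. Compound 3 and compound 1 therefore sit within the scatter of each other, as a 1.6-fold lower number from compound 1 to compound 3 (0.20 log units; within the scatter) shows; this step swaps benzyl in place of 3-methoxyphenyl on a saturated chain carbon, two bonds along the chain from a carbonyl carbon. The other step, an at least 43-fold lower number from compound 2 to compound 3 (1.64 log units; beyond the scatter), puts hydrogen in place of chloro on an aromatic carbon and is large, though its size is only a bound because the limit of > 10000 nM in this assay, at which 1 of the 3 values shown sits, is a limit rather than a number.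

Compound 4, `COc1cccc(CCCC(=O)Nc2nc3ccccc3c(=O)s2)c1`, has not yet been measured. It differs from compound 3 by methoxy in place of hydrogen on an aromatic carbon. The closest guide is the step from compound 1 to compound 3, which removed a methoxy from the same kind of phenyl ring on a slightly shorter chain and stayed within the scatter. Adding the methoxy back on the longer chain of compound 4 is therefore expected to change the number little, with the step of a 1.5-fold higher number from compound 3 to compound 4 (0.18 log units; within the scatter) expected to lie within the scatter. Compound 4 is estimated at 350 nM in this assay, within a range from 150 nM to 900 nM.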

Compound 4, inhibition constant: 22.5 nM
For compound 4 the middle estimate is 16-fold (1.19 log units) above the measured one; the whole stated range lies above it.
By their numbers in this assay, from the lowest: compound 4; then compounds 3 and 1 (each within the scatter of the next). At a limit, above all of these: compound 2.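

In this assay, placing methoxy in place of hydrogen on an aromatic carbon, meta to a large group, gives a 10-fold lower number from compound 3 to compound 4 (1.01 log units; beyond the scatter) and is a large step, so this position on the phenyl ring clearly bears on the number. The earlier step, a 1.6-fold lower number from compound 1 to compound 3 (0.20 log units; within the scatter), stayed within the scatter, but it changed the methoxy and the chain together and so could not show this. With the same 3-methoxyphenyl group, compound 1 on the shorter chain gives 367 nM while compound 4 on the longer chain gives 22.5 nM in this assay, so the methoxy and the chain length have to be read together, and nothing shown here accounts for why the methoxy has this effect.

The compounds shown leave open whether the methoxy itself is needed, since a hydroxyl, a fluoro or an ethoxy on the same aromatic carbon would test that. They also leave open how the number would move with a methoxy on another carbon of the phenyl ring, or with a chain longer than that of compound 4.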